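The compounds below may be only part of what the source reports. "The series", "measured", "known", "first", "only" and "open" are said of these compounds alone.

Compound 1 `O=C(NO)c1ccc(NCc2nc(-c3ccccc3)nn2-c2ccc(Br)cc2)cc1` gives 9300 nM in the test below.
Compound 2 `Cc1ccc(-c2nc(CNc3ccc(C(=O)NO)cc3)n(-c3ccccc3)n2)s1` gives 8450 nM in the same test.

Both numbers come from a functional assay on MGC-803 cells (Homo sapiens) for antiproliferative activity, read by MTT assay, with a stated time of 72 h (on this read-out lower numbers stand for stronger inhibition and higher numbers for weaker inhibition), and they are the only two available so far. Compound 1 holds the higher number on paper, yet compound 2 lies within the scatter of it, so the two cannot be ranked. Compound 3 `Cc1cccc(-n2nc(-c3ccccc3)nc2CNc2ccc(C(=O)NO)cc2)c1` has not been measured yet. Among the measured compounds shown here, its single difference from compound 1 is counted here (3-methylphenyl in place of 4-bromophenyl on an aromatic nitrogen) and reads 3-methylphenyl in place of 4-bromophenyl on an aromatic nitrogen. The rest of the structure is shared. For the measured compounds named here, no measured step shows what this exchange does, so any expectation rests on thin ground. Compound 1 at 9300 nM and compound 2 at 8450 nM sit close together, and nothing measured points in either direction. No step beyond the scatter is therefore expected in this assay for this exchange. The expected step is small (a 1.2-fold lower number from compound 1 to compound 3 (0.07 log units; within the scatter)) and carries wide uncertainty. For compound 3 the estimated value is 8000 nM with an expected range from 3000 nM to 20000 nM in this read-out.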

Compound 3, half-maximal inhibitory concentration: 13200 nM
Beside the measured number, compound 3's estimate is 1.7-fold (0.22 log units) below it, within the range that was stated.
By their numbers in this assay, from the lowest: compounds 2, 1 and 3 (each within the scatter of the next).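

On the aromatic nitrogen of the shared core, 3-methylphenyl in place of 4-bromophenyl gives a 1.4-fold higher number from compound 1 to compound 3 (0.15 log units; within the scatter) in this assay, the first step measured at this position, and the two compounds cannot be ranked. Among the compounds shown here, the two groups match in what is counted: each has 7 heavy atoms and one six-membered aromatic ring of carbon only, with no hydrogen-bond donors, no hydrogen-bond acceptors and no net charge, so this pair shows only that an exchange between two such groups leaves the number within the scatter. Nothing measured alongside these values bears on this result.

This one exchange replaces bromine with methyl and also alters where the substituent sits on the phenyl ring, so the compounds shown cannot separate those two changes. They also leave open whether a different kind of group at this position, such as a phenyl ring carrying an amine or a carboxylic acid, or a longer chain on the aromatic nitrogen, would produce a step beyond the scatter.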